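This account rests on a few compounds, and the source may have more. Where it says the series, first, only, none or still open, it means among the compounds named here.

Compound 1, `O=C1O[C@H]([C@@H](O)Cn2cc(-c3cc(C(F)(F)F)cc(C(F)(F)F)c3)nn2)C(OCc2ccccc2)=C1OCc1ccccc1`, gives 57200 nM in a functional assay on HCT-116 cells (Homo sapiens) for antiproliferative activity, read by MTT assay, with a stated time of 72 h; on this read-out higher numbers stand for weaker inhibition and lower numbers for stronger inhibition. Compound 3, `CCCCCc1ccc(-c2cn(C[C@H](O)[C@H]3OC(=O)C(OCc4ccccc4)=C3OCc3ccccc3)nn2)cc1`, gives 13800 nM in this assay. Compound 2, `O=C1O/C(=C\Cn2cc(-c3cc(F)cc(F)c3)nn2)C(OCc2ccccc2)=C1OCc1ccccc1`, reaches only the limit of > 100000 nM in this assay, a limit and not a number; this is noted in the limit of > 100000 nM in this assay, at which 1 of the 3 values shown sits.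

Among the two numbers shown, compound 3 holds the lower one, and compound 1 sits above it beyond the usual scatter. Compound 4, `O=C1O[C@H]([C@@H](O)Cn2ccnn2)C(OCc2ccccc2)=C1OCc1ccccc1`, differs from compound 3 in one place: hydrogen in place of 4-pentylphenyl on an aromatic carbon. Going by the values given here, no measured step covers this change. Compound 4 is expected to give a higher number than compound 3, a step of a 4.3-fold higher number from compound 3 to compound 4 (0.64 log units; beyond the scatter), because compound 3 gives 13800 nM with its 4-pentylphenyl in place. For compound 4 the estimate is 60000 nM, within 20000 nM to 150000 nM.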

Compound 4, half-maximal inhibitory concentration: > 100000 nM
Compound 4: only a limit was reported (the forecaster's own chance of this, stated with the estimate: 35%); middle value at least 1.6-fold (0.22 log units) from the limit.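

With hydrogen in place of 4-pentylphenyl on this aromatic carbon, this assay gives an at least 7.2-fold higher number from compound 3 to compound 4 (0.86 log units; beyond the scatter). Going by these compounds alone, this is the first step read at this position, and it shows that the activity of compound 3 depends on having a substituent on this carbon. For compound 4 the result is a limit and not a number, so the step gives only a minimum size: the limit of > 100000 nM in this assay, at which 2 of the 4 values shown sit.

The compounds shown leave open how much of the substituent is needed. Whether an unsubstituted phenyl, a shorter alkyl chain or a phenyl bearing an amine would keep the activity of compound 3 remains unanswered.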